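Replacing diisopropylamino with pyrrolidin-1-yl on a thiocarbonyl carbon

A few compounds are considered here, and "the series" means these few. Any claim that something is new, unique, unknown or untested is made for them only; others in the source may bear on it.

Compound 1 `O=c1cc(CSC(=S)N2CCCC2)oc2cc(Cl)ccc12`, compound 2 `CC(C)N(C(=S)SCc1oc2ccccc2c(=O)c1Cl)C(C)C` and compound 3 `CC(C)N(C(=S)SCc1cc(=O)c2ccc(Cl)cc2o1)C(C)C` were each tested in a functional assay on LM7 cells (Homo sapiens) for antiproliferative activity, read by MTT assay, with a stated time of 72 h; a lower number here means a stronger inhibitor, a higher number a weaker inhibitor. Compound 1 gave only a limit of the assay, > 25000 nM, not a number. Compound 2 likewise gave only a limit, > 40000 nM. Compound 3 also stopped at a limit, > 30000 nM. Among the measured compounds shown here, the one measured step, a step that the two limits leave unreadable from compound 3 to compound 1, is pyrrolidin-1-yl in place of diisopropylamino on a thiocarbonyl carbon, and its size stays unreadable because both of its compounds sit at limits (the limit of > 30000 nM in this assay, at which 1 of the 3 values shown sits, and (the limit of > 25000 nM in this assay, at which 1 of the 3 values shown sits)). Compound 4 `O=c1c(Cl)c(CSC(=S)N2CCCC2)oc2ccccc12` has not yet been measured in this assay. For the measured compounds named here, it arises from compound 2 by pyrrolidin-1-yl in place of diisopropylamino on a thiocarbonyl carbon, the same change as the one from compound 3 to compound 1, at the same kind of surroundings. The cores of compound 2 and compound 3 differ, but that difference is not broken down here. The step of a number no higher from compound 2 to compound 4 (the limit leaves the size open) is expected to be small beside a step that the two limits leave unreadable from compound 3 to compound 1, because compound 2 rests at the limit of > 40000 nM in this assay, at which 1 of the 3 values shown sits. Compound 4 is therefore expected near 40000 nM, within 15000 nM to 100000 nM, most likely reported again only as a limit.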

Compound 4, half-maximal inhibitory concentration: 1900 nM
Estimate against measurement, compound 4: 21-fold (1.32 log units) above, and the stated range ends above it.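

In this assay the swap of diisopropylamino for pyrrolidin-1-yl on a thiocarbonyl carbon gives an at least 21-fold lower number from compound 2 to compound 4 (1.32 log units; beyond the scatter) on the core of compound 4, so on this core the change turns a compound stuck at a limit into one with a real number. Compound 1 gives only a limit (> 25000 nM), and compound 3 gives only a limit (> 30000 nM) as well. The step between them cannot be read, so the same change on that other core yields no number, and the large gain is shown for one core only, with neither its size elsewhere nor its reason established.

The compounds shown leave open whether a piperidine ring, a morpholine ring or a simple dimethylamino group on the thiocarbonyl carbon would act as pyrrolidin-1-yl does on the core of compound 4. They also leave open what the difference between the cores does on its own, as compound 2 and compound 3 both rest at limits.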